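The compounds below may be only part of what the source reports. "The series", "measured", "known", "first", "only" and "open" are said of these compounds alone.

Compound 3, with structure `COC(=O)c1sc2ccccc2c1C#Cc1ccccc1F`, is one of three compounds tested in a functional assay on NCI-H460 cells (Homo sapiens) for cytotoxicity, read by sulforhodamine B assay, with a stated time of 48 h; on this read-out higher numbers stand for weaker inhibition of growth and lower numbers for stronger inhibition of growth. Its value in this assay is 25700 nM. Compound 2, with structure `COC(=O)c1sc2cc(OC)ccc2c1C#Cc1ccc(F)cc1`, gives 20900 nM in this assay, and the two numbers lie within the usual scatter of each other, so neither can be set apart from the other. Compound 1, with structure `COC(=O)c1sc2ccccc2c1C#Cc1ccc(OC)cc1`, returns only a limit of the assay, > 150000 nM, and no number (the limit of > 150000 nM in this assay, at which 1 of the 3 values shown sits).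

Compound 4, with structure `COC(=O)c1sc2ccccc2c1C#Cc1ccc(F)cc1`, has not yet been measured in this assay. It differs from compound 3 in one respect: 4-fluorophenyl in place of 2-fluorophenyl on a triple-bonded carbon. For the measured compounds named here, no measured pair in this set shows the effect of such a change on its own, and the pairs that exist each differ in more than one place, so there is nothing to gauge the step against.

The author therefore expects a step from compound 3 to compound 4 of a 1.2-fold higher number from compound 3 to compound 4 (0.07 log units; within the scatter), which is no more than the scatter. Compound 4 is thus estimated at 30000 nM, with a range from 8000 nM to 120000 nM.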

Compound 4, concentration for 50% growth inhibition: 76100 nM
Compound 4: the middle estimate sits 2.5-fold (0.40 log units) below what was measured; the range from low to high includes it.
By their numbers in this assay, from the lowest: compounds 2 and 3 (each within the scatter of the next); then compound 4. At a limit, above all of these: compound 1.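

In this assay, 4-fluorophenyl in place of 2-fluorophenyl on a triple-bonded carbon gives a 3.0-fold higher number from compound 3 to compound 4 (0.47 log units; beyond the scatter), so where the fluorine sits on this ring changes the number even though the two groups have the same atoms. Hydrogen in place of methoxy on an aromatic carbon gives a 3.6-fold higher number from compound 2 to compound 4 (0.56 log units; beyond the scatter), which shows that this second place also matters when compound 4 carries the 4-fluorophenyl group. Fluoro in place of methoxy on an aromatic carbon gives an at least 1.9-fold lower number from compound 1 to compound 4 (0.29 log units; that floor lies within the scatter), and this step rests on a limit, not a number: the limit of > 150000 nM in this assay, at which 1 of the 4 values shown sits.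

The compounds shown leave open whether the methoxy step would be the same with 2-fluorophenyl in place of 4-fluorophenyl. They also leave open how chloro in place of fluoro, or a carboxylic acid in place of the methyl ester, would change the number.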